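Lengthening the Chain Toward the Azepane Ring

The compounds below may be only part of what the source reports. "The series", "measured", "known", "first", "only" and "open" are said of these compounds alone.

Two measured compounds share a core that carries a saturated chain ending in an azepan-1-yl group. Compound 1 `O=c1sc2ccccc2n1CCCCCN1CCCCCC1` is the plainer of the two; in an assay on cell membranes for displacement of a labelled ligand from Sigma non-opioid intracellular receptor 1 (Rattus norvegicus) (a lower number here means a stronger inhibitor, a higher number a weaker inhibitor), compound 1 gives 7 nM. Compound 2 `CCCc1ccc2c(c1)sc(=O)n2CCCCN1CCCCCC1` adds a propyl group and uses a shorter chain; in this assay compound 2 gives 6.1 nM. Compound 2 has the lower of the two numbers shown, yet compound 1 sits so close that the two values fall within the usual scatter, so no order between them can be read.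

Compound 3 `CCCc1ccc2c(c1)sc(=O)n2CCCCCN1CCCCCC1` has not yet been measured. It differs from compound 2 in one place: (azepan-1-yl)methyl in place of azepan-1-yl on a saturated chain carbon, four bonds along the chain from an aromatic nitrogen. Among the measured compounds shown here, no measured pair isolates this change, so its effect is not known from the data. Compound 1, with its value of 7 nM, shows that the longer chain is compatible with a low number, so the step from compound 2 to compound 3 is expected to be small, a 1.2-fold lower number from compound 2 to compound 3 (0.09 log units; within the scatter), or none beyond the scatter. Compound 3 is therefore expected to give about 5 nM in this assay, with a likely range from 2 nM to 15 nM.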

Compound 3, inhibition constant: 4.6 nM
Compound 3: the middle estimate sits 1.1-fold (0.04 log units) above what was measured; the range from low to high includes it.
By their numbers in this assay, from the lowest: compounds 3, 2 and 1 (each within the scatter of the next).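

In this assay, the swap of azepan-1-yl for (azepan-1-yl)methyl on a saturated chain carbon, four bonds along the chain from an aromatic nitrogen, now has a measured pair: it gives a 1.3-fold lower number from compound 2 to compound 3 (0.12 log units; within the scatter), so this one-carbon change to the chain has no effect that can be told apart from repeat-measurement noise. Among the compounds shown here, the new compound also isolates a second change for the first time, propyl in place of hydrogen on an aromatic carbon, which gives a 1.5-fold lower number from compound 1 to compound 3 (0.18 log units; within the scatter) and likewise cannot be distinguished from no effect. No accompanying measurement bears on these results.

With all the steps inside the scatter, the compounds shown leave open how far this chain can be changed before the number really moves, for example with a longer chain ending in the same azepan-1-yl group. They also leave open whether a butyl group in place of the propyl, or an open-chain amine in place of the azepan-1-yl group, would produce a step beyond the scatter.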